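Taking the fluoro off compound 1: what to expect

The source may report more compounds than this note shows. Statements on the series, on what has been measured and on what is new or still open speak of the compounds shown alone.

Measured in a functional assay on DU-145 cells (Homo sapiens) for cytotoxicity (a higher number here means a weaker inhibitor, a lower number a stronger inhibitor), so far:
Compound 1, `O=C(N/N=C\c1cn(Cc2ccc(Cl)cc2)c2cc(F)ccc12)c1c[nH]c2ccccc12`: 18600 nM
Compound 2, `COc1ccc(Cn2cc(/C=N\NC(=O)c3c[nH]c4ccccc34)c3ccc(F)cc32)cc1`: 16200 nM
Compound 3, `O=C(N/N=C\c1cn(Cc2ccc(Cl)cc2)c2cc(F)ccc12)c1c[nH]c2ccc(Br)cc12`: 12500 nM

Compound 1 gives the highest number of the three, but nothing separates it from its neighbours: the step of a 1.1-fold lower number from compound 1 to compound 2 (0.06 log units; within the scatter) and the step of a 1.5-fold lower number from compound 1 to compound 3 (0.17 log units; within the scatter) both fall within the usual scatter of this assay, so compound 1, compound 2 and compound 3 are indistinguishable on the numbers available.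

Compound 4, `O=C(N/N=C\c1cn(Cc2ccc(Cl)cc2)c2ccccc12)c1c[nH]c2ccccc12`, has not yet been measured. It differs from compound 1 in one place: hydrogen in place of fluoro on an aromatic carbon. Neither measured step bears on this change directly. The step from compound 1 to compound 2 exchanges one group for another, and the step from compound 1 to compound 3 adds a bromo; neither touches the fluoro, and both stayed within the scatter. Among the compounds with values here, there is no measured precedent for removing the fluoro. With the two nearby changes giving no step beyond the scatter, the expectation for compound 4 in this assay is a step no larger than the scatter, in either direction, so a 1.0-fold lower number from compound 1 to compound 4 (0.01 log units; within the scatter) is estimated to be small. Compound 4 is therefore expected to give 18000 nM, with a range from 7000 nM to 45000 nM.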

Compound 4, half-maximal inhibitory concentration: 52100 nM
Compound 4: the middle estimate sits 2.9-fold (0.46 log units) below what was measured, outside the stated range (above it).
By their numbers in this assay, from the lowest: compounds 3, 2 and 1 (each within the scatter of the next); then compound 4.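

In this assay, within the data shown here, the fluoro on the shared core is the first place in this small set where a single change moves the number beyond the scatter: a 2.8-fold higher number from compound 1 to compound 4 (0.45 log units; beyond the scatter), a modest step, with the compound that has hydrogen on this aromatic carbon giving the higher number and so counting as the weaker inhibitor. The two earlier changes, methoxy in place of chloro and bromo in place of hydrogen, had left the numbers within the scatter, so this position is the only one of the three sites of change shown where replacing the group separates two compounds. Nothing measured here accounts for the shift.

The compounds shown leave open whether the step belongs to fluoro itself or whether another group on this aromatic carbon, such as a chloro, a nitrile or an amine, would give a number like that of compound 1. From the compounds shown here alone, it also remains open whether taking off the fluoro would produce a similar step in compound 2 or compound 3, and this single pair sets no pattern for the series.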